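This account rests on a few compounds, and the source may have more. Where it says the series, first, only, none or still open, it means among the compounds named here.

Phenoxy for isopropoxy on a shared indole-free scaffold? No — keep title plain:

Swapping isopropyl for phenyl on the ether oxygen

Compound 3 `Cc1nc(-c2cc3cc(OC(C)C)cc(C#N)c3[nH]2)sc1C(=O)O` is one of three close analogues measured in an ADME assay on liver for metabolic stability, with Liver microsome (Rattus norvegicus) as the target, using microsomes (on this read-out higher numbers stand for a longer-lived compound and lower numbers for a shorter-lived compound), where compound 3 gives 2.17 h. Compound 1 `Cc1nc(-c2cc3cc(NCc4ccccc4)cc(C#N)c3[nH]2)sc1C(=O)O` gives 1.5 h in this assay, and compound 2 `Cc1nc(-c2cc3cc(Oc4ccccc4)cc(Br)c3[nH]2)sc1C(=O)O` gives 1.52 h. Among the compounds with values here, all three numbers lie within the usual scatter of one another, so none of them can be set apart from the others; the only single-point step among them, a 1.4-fold higher number from compound 1 to compound 3 (0.16 log units; within the scatter), confirms this.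

Compound 4 `Cc1nc(-c2cc3cc(Oc4ccccc4)cc(C#N)c3[nH]2)sc1C(=O)O` differs from compound 3 by phenyl in place of isopropyl on an oxygen on an aromatic ring. Within the data shown here, the one measured step that touches this group is the step from compound 1 to compound 3, which exchanged benzylamino for isopropoxy without moving the half-life beyond the scatter. Compound 2 already carries the phenoxy group that enters here, though with bromine rather than nitrile on the core, and its number and that of compound 3 sit close together. Nothing in these data therefore points to a change of any direction.

Compound 4 is accordingly expected to give about 1.7 h in this assay, within a range of 0.9 h to 3.2 h. The estimated step of a 1.3-fold lower number from compound 3 to compound 4 (0.11 log units; within the scatter) is expected to stay within the scatter.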

Compound 4, half-life: 3.68 h
Estimate against measurement, compound 4: 2.2-fold (0.34 log units) below; measured number outside the range, above it.
By their numbers in this assay, from the lowest: compounds 1, 2, 3 and 4 (each within the scatter of the next, the first and the last beyond it).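

In this assay, phenyl in place of isopropyl on an oxygen on an aromatic ring gives a 1.7-fold higher number from compound 3 to compound 4 (0.23 log units; within the scatter) and so the two numbers cannot be set apart, which shows that this position accepts the six-carbon aromatic ring as well as the three-carbon isopropyl group. Within the data shown here, compound 4 also gives the first steps in this set that lie beyond the scatter: cyano in place of bromo on an aromatic carbon gives a 2.4-fold higher number from compound 2 to compound 4 (0.38 log units; beyond the scatter) and phenoxy in place of benzylamino on an aromatic carbon gives a 2.5-fold higher number from compound 1 to compound 4 (0.39 log units; beyond the scatter) as a second modest step. Among these compounds, the half-life of this series can therefore be moved by single changes, though only modestly, and with phenoxy on the core the nitrile compound stands apart from the bromo compound, a difference the earlier compounds could not show.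

From the compounds shown here alone, it remains open whether an amine, a longer alkyl chain or a phenyl ring bearing fluorine on this oxygen-linked position would keep the number of compound 4 or lose it. Why these steps take the size they do also stays open, as no measurement here speaks to the cause of the result.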